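Removing the chloro from an inactive benzopyranone thioether

The compounds below may be only part of what the source reports. "The series", "measured", "known", "first", "only" and "open" are said of these compounds alone.

Compound 1 `Cc1cc(C)nc(SCc2cc(=O)c3cc(Cl)ccc3o2)n1` gives > 25000 nM in a functional assay on HeLa cells (Homo sapiens) for cytotoxicity, read by MTT assay, with a stated time of 72 h; on this read-out lower numbers stand for stronger inhibition and higher numbers for weaker inhibition.
Compound 2 `Cc1cc(C)nc(SCc2coc3ccccc3c2=O)n1` gives > 25000 nM in this assay.

For compound 1 this value is a limit of the assay, not a number. The same holds for compound 2. Compound 1 therefore sits at the limit of > 25000 nM in this assay, at which 2 of the 2 values shown sit. Compound 3 `Cc1cc(C)nc(SCc2cc(=O)c3ccccc3o2)n1` differs from compound 1 by hydrogen in place of chloro on an aromatic carbon. Going by the values given here, no step between measured compounds is available, so the size of this change cannot be read from the data. Since compound 1 stands at the limit of > 25000 nM in this assay, at which 2 of the 2 values shown sit, compound 3 is expected to remain at the limit, with an expected step that the limit leaves unreadable from compound 1 to compound 3 not reaching beyond the scatter. Compound 3 is estimated at 50000 nM, between 20000 nM and 200000 nM.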

Compound 3, half-maximal inhibitory concentration: > 25000 nM
Compound 3: only a limit was reported (the forecaster's own chance of this, stated with the estimate: 85%); the middle value is on the limit's open side.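

Going by these compounds alone, compound 3 gives > 25000 nM, a limit of the assay and not a number, so no step from compound 1 to compound 3 can be read: the limit of > 25000 nM in this assay, at which 3 of the 3 values shown sit. The compounds shown leave open whether hydrogen in place of chloro changes the activity at all, and which change to the shared core would give a readable value.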